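This account rests on a few compounds, and the source may have more. Where it says the series, first, only, none or still open, it means among the compounds named here.

Among the measured compounds shown here, in a functional assay on HL-60 cells (Homo sapiens) for cytotoxicity, read by MTT assay, with a stated time of 96 h (a lower number here means a stronger inhibitor, a higher number a weaker inhibitor), compound 1 `CC[C@H](NC)C(=O)N[C@@H]1C(=O)N2[C@@H](CC[C@@H]1CN)CC[C@H]2C(=O)NC(c1ccccc1)c1ccccc1` gives 51800 nM, the only exact number available so far and a high one on this scale. Compound 2 `CC[C@H](N)C(=O)N[C@@H]1C(=O)N2[C@@H](CC[C@@H]1CCO)CC[C@H]2C(=O)NC(c1ccccc1)c1ccccc1` is reported only as a limit, > 100000 nM. Compound 3 `CC[C@H](NC)C(=O)N[C@@H]1C(=O)N2[C@@H](CC[C@@H]1CCNC(=O)NCc1ccccc1)CC[C@H]2C(=O)NC(c1ccccc1)c1ccccc1` differs from compound 1 at one place, with ((benzylcarbamoyl)amino)methyl in place of amino on a saturated chain carbon bound to a saturated ring carbon. For the measured compounds named here, no measured pair shows a comparable change, so the size of this step has to be judged with wide uncertainty. Compound 1 at 51800 nM leaves ample room on the scale toward stronger inhibition, so a modest gain is expected rather than a large one. The expected step is a 2.1-fold lower number from compound 1 to compound 3 (0.32 log units; beyond the scatter), and it may not clear the usual scatter by much. For compound 3 the estimated value is 25000 nM, with an expected range of 6000 nM to 90000 nM.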

Compound 3, half-maximal inhibitory concentration: 52200 nM
Estimate against measurement, compound 3: 2.1-fold (0.32 log units) below, within the range that was stated.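

In this assay the result is a 1.0-fold higher number from compound 1 to compound 3 (0.00 log units; within the scatter). On a saturated chain carbon bound to a saturated ring carbon, amino with its 1 heavy atom and ((benzylcarbamoyl)amino)methyl with its 12 heavy atoms and aromatic ring therefore give numbers that match within the usual scatter. Among the compounds shown here, this pair is the first to differ in one place only, and it shows that this place can carry a much larger group without the number leaving that scatter.

Going by these compounds, whether a carboxylic acid or a simple hydroxyl on this carbon would shift the number in either direction remains open, as a single pair cannot show that. Compound 2 is reported only as a limit, not a number, so it offers no step here: the limit of > 100000 nM in this assay, at which 1 of the 3 values shown sits.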